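Sulfonyl substituent change in the series: working notes

The compounds below may be only part of what the source reports. "The series", "measured", "known", "first", "only" and "open" are said of these compounds alone.

In a functional assay for inhibition, with Homo sapiens as the target (a lower number here means a stronger inhibitor, a higher number a weaker inhibitor), compound 1 `CCCCCS(=O)(=O)N[C@@H](CNC(=O)c1ccc2c(c1)C(=O)N(CCC1CCNCC1)C2)C(=O)O` gives 9 nM. Compound 2 `CCOCCS(=O)(=O)N[C@@H](CNC(=O)c1ccc2c(c1)C(=O)N(CCC1CCNCC1)C2)C(=O)O` gives 8 nM, so the two compounds cannot be told apart on these numbers, and compound 2 stands level with compound 1 within the scatter.

Compound 3 `O=C(NC[C@H](NS(=O)(=O)c1cccs1)C(=O)O)c1ccc2c(c1)C(=O)N(CCC1CCNCC1)C2` changes the same substituent: thiophen-2-yl in place of 2-ethoxyethyl on a sulfonyl sulfur. In short, thiophen-2-yl stands in place of 2-ethoxyethyl on a sulfonyl sulfur.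

Among the measured compounds shown here, only one measured step bears on this substituent. It is a 1.1-fold lower number from compound 1 to compound 2 (0.05 log units; within the scatter), which stays within the scatter. That step replaces one saturated chain with another, so it says little about a ring at this place. For the measured compounds named here, no compound with a ring on the sulfonyl sulfur has been measured yet, and the data give no direction for the change. The working expectation is therefore no clear shift, with a wide margin for the untested ring.

The estimated step is a 1.3-fold higher number from compound 2 to compound 3 (0.10 log units; within the scatter), expected to stay small. Compound 3 is expected at 10 nM, with an estimated range of 3 nM to 30 nM.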

Compound 3, half-maximal inhibitory concentration: 7 nM
For compound 3 the middle estimate is 1.4-fold (0.15 log units) above the measured one; low and high end bracket the measured number.
By their numbers in this assay, from the lowest: compounds 3, 2 and 1 (each within the scatter of the next).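

Thiophen-2-yl is the first ring on the sulfonyl sulfur in this set, and in this assay the reading is a 1.1-fold lower number from compound 2 to compound 3 (0.06 log units; within the scatter); against the pentyl compound the reading is a 1.3-fold lower number from compound 1 to compound 3 (0.11 log units; within the scatter). At this place, on a sulfonyl sulfur whose other neighbour is the sulfonamide nitrogen, a five-membered aromatic ring with 1 hetero atom therefore cannot be told apart from either open chain, which widens the earlier chain-for-chain comparison to a ring-for-chain one. No supporting data bear on why these three compounds stand level, so the result remains a plain observation on potency.

Still open, going by these compounds, is whether the same level reading extends to a phenyl ring, to a thiophen-2-yl carrying a chlorine, or to a chain ending in an amine. Among the compounds shown, no substituent on the sulfonyl sulfur moves the number beyond the scatter, so how much this place can affect inhibition, and in which direction, remains unknown.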